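Two Chlorines on the Phenyl of Compound 3

The source may hold more compounds than are shown below. What is called first, only, known or untested is meant among the compounds shown, and "the series" means these compounds.

Compound 1 `COc1cc(/C=C/C(=O)C2=C(/C=C/c3ccc(O)c(OC)c3)NC(=O)NC2c2ccccc2)ccc1O`: 10.5% in a functional assay, with a stated time of 20 min, tested at 2 uM; a higher number here means a stronger effect of the compound at the concentration tested, a lower number a weaker effect
Compound 2 `COc1cc(/C=C/C(=O)C2=C(/C=C/c3ccc(O)c(OC)c3)NC(=O)NC2c2ccccc2O)ccc1O`: 29.9%
Compound 3 `COc1cc(/C=C/C(=O)C2=C(/C=C/c3ccc(O)c(OC)c3)NC(=S)NC2c2ccccc2)ccc1O`: 16.6%

Compound 3 holds the second highest of the three numbers; it sits within the scatter of compound 1 and beyond the scatter below compound 2. Compound 4 `COc1cc(/C=C/C(=O)C2=C(/C=C/c3ccc(O)c(OC)c3)NC(=S)NC2c2c(Cl)cccc2Cl)ccc1O` differs from compound 3 in one place: 2,6-dichlorophenyl in place of phenyl on a saturated ring carbon. Among the measured compounds shown here, the only measured step, a number 19.4 percentage points higher from compound 1 to compound 2 (beyond the scatter), also changes this phenyl, but with a hydroxy rather than chlorine, so it bears on the new step only loosely. For the measured compounds named here, with no measured step involving chlorine, the expectation for compound 4 is no step beyond the scatter, a number 1.4 percentage points higher from compound 3 to compound 4 (within the scatter). Compound 4 is therefore estimated at 18%, within a range from 4% to 36%.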

Compound 4, a percentage reported as activity, at one concentration (the size of the read-out at that concentration, not a potency): 15%
The estimate for compound 4 lay 3 percentage points above the measured number; measured number inside the range.
By their numbers in this assay, from the lowest: compounds 1, 4 and 3 (each within the scatter of the next); then compound 2.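

In this assay, 2,6-dichlorophenyl in place of phenyl on the saturated ring carbon gives a number 1.6 percentage points lower from compound 3 to compound 4 (within the scatter), so this phenyl carries two chlorines while compound 3 and compound 4 remain indistinguishable. The earlier hydroxy step at this phenyl, a number 19.4 percentage points higher from compound 1 to compound 2 (beyond the scatter), lay beyond the scatter; the chlorine step does not. Nothing measured here offers an explanation for this result. Still open, from the compounds shown here alone, is whether a hydroxy on the phenyl of compound 3 would raise the read-out as it did in compound 2. Going by these compounds, how an amine or a carboxylic acid on this phenyl would read out also remains open.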